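Swapping the aryl group on the sulfonyl sulfur of compound 1

This account rests on a few compounds, and the source may have more. Where it says the series, first, only, none or still open, it means among the compounds named here.

Measured compounds:
- compound 1, `Cc1ccc(C)c(S(=O)(=O)NCCCCCCNCc2ccc(Br)cc2)c1`: 12000 nM
- compound 2, `O=S(=O)(NCCCNCc1cccc2ccccc12)c1cc(C(F)(F)F)cc(C(F)(F)F)c1`: 2800 nM
- compound 3, `O=S(=O)(NCCCCNCc1ccc(Br)cc1)c1cc(C(F)(F)F)cc(C(F)(F)F)c1`: 2100 nM

All three were tested in a functional assay on MIA PaCa-2 cells (Homo sapiens) for inhibition, read by MTT assay, with a stated time of 72 h; on this read-out higher numbers stand for weaker inhibition of growth and lower numbers for stronger inhibition of growth. Among them, compound 1 gives the highest number, 12000 nM. The nearest is compound 2 with 2800 nM, a gap beyond the scatter, and compound 3 with 2100 nM lies furthest, also beyond the scatter. Compounds 2 and 3 share the same group on the sulfonyl sulfur, so these gaps cannot be traced to any single change.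

Compound 4, `O=S(=O)(NCCCCCCNCc1ccc(Br)cc1)c1ccc(Cl)cc1`, is not yet measured. It differs from compound 1 in one place: 4-chlorophenyl in place of 2,5-dimethylphenyl on a sulfonyl sulfur. Among the measured compounds shown here, no measured pair isolates this kind of exchange, so the account rests on compound 1 alone.

The expected step of a 1.5-fold lower number from compound 1 to compound 4 (0.18 log units; within the scatter) is a modest move toward a lower number, of a size that may not exceed the scatter. Compound 4 is therefore estimated at 8000 nM, with a range from 2500 nM to 25000 nM.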

Compound 4, concentration for 50% growth inhibition: 5900 nM
Estimate against measurement, compound 4: 1.4-fold (0.13 log units) above; low and high end bracket the measured number.
By their numbers in this assay, from the lowest: compounds 3 and 2 (each within the scatter of the next); then compound 4; then compound 1.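

In this assay, among the compounds shown here, the exchange of 2,5-dimethylphenyl for 4-chlorophenyl on the sulfonyl sulfur gives a 2.0-fold lower number from compound 1 to compound 4 (0.31 log units; beyond the scatter) and is the first single change that can be read in this set. It shows that this position responds to the aryl group, if modestly, even though both groups hold one six-membered aromatic ring of carbon only, no hydrogen-bond donors or acceptors and no net charge. No measurement of any property here bears on why the number moves.

The compounds shown do not separate the gain of the chlorine from the loss of the two methyl groups. Also open, as far as these compounds go, is how plain phenyl, 4-methylphenyl, 4-methoxyphenyl or a pyridine ring would fare on the same sulfur with the rest of compound 1 unchanged.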